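A few compounds are considered here, and "the series" means these few. Any claim that something is new, unique, unknown or untested is made for them only; others in the source may bear on it.

Compound 1 `N=C(N)NCCC[C@H](NC(=O)CN(c1nc(Cl)nc2[nH]cnc12)C1CC1)C(=O)O` gives 45.4% in a functional assay on the whole organism (Tail, strain ICR) with Mus musculus as the target, in the tail flick test, with a stated time of 30 min, at a dose of 25 umol/kg by the oral route (on this read-out lower numbers stand for a weaker effect and higher numbers for a stronger effect at the one dose given), the highest of the three numbers recorded there. Compound 2 `N=C(N)NCCC[C@H](NC(=O)CN(c1nc(Cl)nc2[nH]cnc12)C1CC1)C(=O)OCc1ccccc1` gives 23.2%. The step of a number 22.2 percentage points lower from compound 1 to compound 2 (beyond the scatter) goes with a benzyl in place of hydrogen on an oxygen next to a carbonyl group. Compound 3 `CSCC[C@H](NC(=O)CN(c1ncnc2c1ncn2C1CCCCO1)C1CC1)C(=O)OCc1ccccc1` gives 30%; it differs from compound 1 in more than one place, so its number only shows where it stands. Compound 4 `CC(C)C[C@H](NC(=O)CN(c1nc(Cl)nc2[nH]cnc12)C1CC1)C(=O)O` differs from compound 1 by a group of 3 heavy atoms (3 carbon; no ring) in place of a group of 6 heavy atoms (3 carbon, 3 nitrogen; no ring), on a saturated chain carbon, two bonds along the chain from an amide-type nitrogen and a carbonyl carbon. Within the data shown here, no measured step touches this chain carbon, so the expectation rests on the general spread of the series rather than on a matching change. The account expects a modest fall, a number 15.4 percentage points lower from compound 1 to compound 4 (beyond the scatter), and for compound 4 an estimated 30%, within a range from 10% to 50%.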

Compound 4, a percentage reported as activity, at one dose (the size of the read-out at that dose, not a potency): 23.4%
Estimate against measurement, compound 4: 6.6 percentage points above, within the range that was stated.
By their numbers in this assay, from the lowest: compounds 2, 4 and 3 (each within the scatter of the next); then compound 1.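

In this assay, the saturated chain carbon, two bonds along the chain from an amide-type nitrogen and a carbonyl carbon, now has a measured step: isopropyl in place of the group of 6 heavy atoms goes with a number 22 percentage points lower from compound 1 to compound 4 (beyond the scatter). The read-out therefore responds to a change at this carbon, not only to the earlier change on the oxygen. No measurement given here accounts for this fall.

As far as these compounds go, whether an amine or a longer carbon chain at this carbon would restore the value of compound 1 remains open. The nitrogen atoms and the size of the group therefore cannot be told apart.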